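The source may hold more compounds than are shown below. What is called first, only, known or untested is meant among the compounds shown, and "the series" means these compounds.

In a functional assay for inhibition, with Homo sapiens as the target (a lower number here means a stronger inhibitor, a higher number a weaker inhibitor), compound 1 (`Cc1cc(C)cc(Nc2nccc(-c3ccccn3)n2)c1`) gives 100 nM. Compound 2 (`c1cc(Nc2nccc(-c3ccncc3)n2)cc(OCCn2ccnc2)c1`) gives 200 nM and lies within the scatter of compound 1. Compound 3 (`COc1cccc(Nc2nccc(-c3cccnc3)n2)c1`) gives 300 nM and lies beyond the scatter of compound 1, with a higher number. Compound 4 (`Cc1cc(C)cc(Nc2nccc(-c3cccnc3)n2)c1`) differs from compound 1 in one group (pyridin-3-yl in place of pyridin-2-yl on an aromatic carbon): pyridin-3-yl in place of pyridin-2-yl on an aromatic carbon. Among the measured compounds shown here, no measured pair isolates this change. For the measured compounds named here, the only guide is compound 3, which also carries pyridin-3-yl and gives 300 nM in this assay, so a small rise is expected. The expected step is a 1.8-fold higher number from compound 1 to compound 4 (0.26 log units; within the scatter), towards a weaker inhibitor and not clearly beyond the scatter. For compound 4 the estimated value is 180 nM, with an expected range from 60 nM to 500 nM.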

Compound 4, half-maximal inhibitory concentration: 800 nM
For compound 4 the middle estimate is 4.4-fold (0.65 log units) below the measured one, outside the stated range (above it).
By their numbers in this assay, from the lowest: compounds 1, 2 and 3 (each within the scatter of the next, the first and the last beyond it); then compound 4.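

In this assay, replacing pyridin-2-yl with pyridin-3-yl gives an 8.0-fold higher number from compound 1 to compound 4 (0.90 log units; beyond the scatter) and so shows that this position, on the aromatic carbon next to the ring nitrogen, responds to how the attached ring is joined, even though both groups have the same atoms. The earlier compounds shown here differ in more than one place and could not isolate this change. Nothing available explains the step. The compounds shown leave open how a phenyl group, without a ring nitrogen, would compare at this position. They also leave open whether an amine on the pyridin-2-yl ring would keep the value of compound 1 at 100 nM.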